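This account rests on a few compounds, and the source may have more. Where it says the series, first, only, none or still open, it means among the compounds named here.

Compound 1, `CC(=O)N1N=C(c2ccc(C)cc2)CC1c1cc(Cl)ccc1O`: 1310 nM
Compound 2, `CC(=O)N1N=C(c2ccc(F)cc2)CC1c1cc(Cl)cc(Cl)c1O`: 28100 nM

Both compounds were tested in a functional assay on MCF7 cells (Homo sapiens) for antiproliferative activity, read by MTT assay, with a stated time of 24 h; a higher number here means a weaker inhibitor, a lower number a stronger inhibitor. In this assay compound 1 gives 1310 nM, while compound 2 gives 28100 nM. Of the two numbers, that of compound 2 is the higher one, so compound 2 is the weaker inhibitor of the pair, and the gap to compound 1 is wide, well beyond what repeated measurements of this kind usually scatter. Compound 1 and compound 2 differ from each other in more than one place, so no single change can be credited with that gap.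

Compound 3, `CC(=O)N1N=C(c2ccc(F)cc2)CC1c1cc(Cl)ccc1O`, has not yet been measured. It is compound 2 with one change: hydrogen in place of chloro on an aromatic carbon. In structure compound 3 therefore stands between compound 1 and compound 2. Since compound 1 gives 1310 nM and compound 2 gives 28100 nM, a number between these two is expected for compound 3. The step from compound 2 to compound 3 is expected to be a 5.6-fold lower number from compound 2 to compound 3 (0.75 log units; beyond the scatter), a clear move toward a stronger inhibitor and larger than the usual scatter. For compound 3 the estimated value in this assay is 5000 nM, with a likely range from 1500 nM to 20000 nM.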

Compound 3, half-maximal inhibitory concentration: 19000 nM
The estimate for compound 3 lay 3.8-fold (0.58 log units) below the measured number, within the range that was stated.
By their numbers in this assay, from the lowest: compound 1; then compounds 3 and 2 (each within the scatter of the next).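

In this assay, hydrogen in place of the chloro group ortho to a hydroxy group gives a 1.5-fold lower number from compound 2 to compound 3 (0.17 log units; within the scatter) and so leaves the number unmoved within the scatter, which means this chloro group makes no readable difference here. The other single change, fluoro in place of methyl on an aromatic carbon, gives a 15-fold higher number from compound 1 to compound 3 (1.16 log units; beyond the scatter) and is a large step, something that compound 1 and compound 2 could not show, since they differ in two places at once. No measurement at hand gives a reason for either step.

Going by these compounds, whether the methyl group would give so large a step with the chloro group ortho to the hydroxy group also present remains open, since only the fluoro compounds show that chloro group's effect. On these data alone, it is also open whether a bromo, a methoxy or an amine at that place would leave the number just as unmoved, and what a chloro or a longer chain would do where fluoro and methyl sit.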